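Indolyl group swap on a nitrogen in a weak pair

A few compounds are considered here, and "the series" means these few. Any claim that something is new, unique, unknown or untested is made for them only; others in the source may bear on it.

Measured so far in a functional assay on DU-145 cells (Homo sapiens) for inhibition, read by trypan blue exclusion, with a stated time of 72 h; on this read-out higher numbers stand for weaker inhibition and lower numbers for stronger inhibition
compound 1 `Cn1c(=O)c(S(=O)(=O)c2ccc(F)cc2F)cc2cnc(Nc3ccncn3)nc21` gives 50000 nM
compound 2 `Cn1c(=O)c(S(=O)(=O)c2ccc(F)cc2F)cc2cnc(NCc3ccc4[nH]ccc4c3)nc21` gives 100000 nM

Among the measured compounds shown here, compound 2 stands level with the only other measured compound, within the scatter. Compound 3 `Cc1cc2cc(Nc3ncc4cc(S(=O)(=O)c5ccc(F)cc5F)c(=O)n(C)c4n3)ccc2[nH]1` differs from compound 2 by one change on a nitrogen on an aromatic ring (2-methyl-1H-indol-5-yl in place of (1H-indol-5-yl)methyl on a nitrogen on an aromatic ring). For the measured compounds named here, the one measured step, a 2.0-fold higher number from compound 1 to compound 2 (0.30 log units; within the scatter), also exchanged the group on that nitrogen and stayed within the scatter. No larger shift is therefore expected in this assay. The expected size is a 2.0-fold lower number from compound 2 to compound 3 (0.30 log units; within the scatter). For compound 3 the estimated value is 50000 nM (expected range 6000 nM to 100000 nM).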

Compound 3, half-maximal inhibitory concentration: 750 nM
Estimate against measurement, compound 3: 67-fold (1.82 log units) above; measured number outside the range, below it.
By their numbers in this assay, from the lowest: compound 3; then compounds 1 and 2 (each within the scatter of the next).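

In this assay the group on this nitrogen clearly matters: 2-methyl-1H-indol-5-yl in place of (1H-indol-5-yl)methyl gives a 130-fold lower number from compound 2 to compound 3 (2.12 log units; beyond the scatter) even though both groups have the same heavy-atom count, and in place of pyrimidin-4-yl it gives a 67-fold lower number from compound 1 to compound 3 (1.82 log units; beyond the scatter) as well. The earlier step within the scatter therefore did not show a flat position, and compound 3 alone stands clear of the other two. No evidence at hand explains this drop.

Still open, as far as these compounds go, is whether the step comes from the methyl on the indole or from the loss of the methylene link; a plain 1H-indol-5-yl on this nitrogen would separate the two. From the compounds shown here alone, how an amine or a carboxylic acid on the indole would read also remains open.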